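Iodo to Bromo on a Shared Core

The compounds below may be only part of what the source reports. "The series", "measured", "known", "first", "only" and "open" are said of these compounds alone.

Measured compounds and their results:
- compound 1, `Nc1ccc(-c2nc3cc(F)ccc3s2)cc1I`: 280 nM
- compound 2, `Cc1cc(-c2nc3ccc(F)cc3s2)ccc1N`: > 100000 nM
- compound 3, `Cc1cc(-c2nc3c(F)cccc3s2)ccc1N`: 1700 nM

All three were tested in a functional assay on OVCAR-5 cells (Homo sapiens) for inhibition; a lower number here means a stronger inhibitor of growth, a higher number a weaker inhibitor of growth. Compound 1 gives 280 nM and stands as the lowest of the two actual numbers. Compound 3 gives 1700 nM, a gap to compound 1 that lies beyond the usual scatter. Compound 2 reaches only the limit of this assay, (the limit of > 100000 nM in this assay, at which 1 of the 3 values shown sits), so no number is known for it. Among the compounds with values here, no two measured compounds differ in just one place, so no single step can be read off among them.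

Compound 4, `Nc1ccc(-c2nc3cc(F)ccc3s2)cc1Br`, has not yet been measured. It differs from compound 1 in one place:
bromo in place of iodo on an aromatic carbon

Iodo and bromo are both halogens, so the change is modest. A small step is expected, if any, leaning toward a somewhat weaker inhibitor of growth, but one that may well stay within the scatter. In this assay compound 4 is estimated to give 500 nM, with a range from 150 nM to 1600 nM. The step expected from this estimate, a 1.8-fold higher number from compound 1 to compound 4 (0.25 log units; within the scatter), rests on compound 1 and its value 280 nM.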

Compound 4, concentration for 50% growth inhibition: 50 nM
Estimate against measurement, compound 4: 10-fold (1.00 log units) above; the whole stated range lies above it.
By their numbers in this assay, from the lowest: compound 4; then compound 1; then compound 3. At a limit, above all of these: compound 2.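

In this assay, the group on this aromatic carbon, ortho to an amino group, proves to matter: putting bromo in place of iodo gives a 5.6-fold lower number from compound 1 to compound 4 (0.75 log units; beyond the scatter), a step beyond the usual scatter. Within the data shown here, no two of the earlier compounds differ in just one place, so this is the first single change that can be read in the set, and it shows that exchanging one halogen for another here is not a silent move: on this core, the bromo compound is the stronger inhibitor of growth, not the iodo compound. Nothing given here accounts for this gain, and the one available note, which concerns the assay limit reached by a different compound, has no bearing on this change.

The compounds shown leave open whether chloro or fluoro on the same carbon would go further in this direction, or whether the gain is particular to bromo. On these data alone, it also remains open how a methoxy group or a nitrile would fare there, and whether the bromo gain would hold with the fluoro moved elsewhere on the shared core.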